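Working note: from compound 2 to compound 3

The source may report more compounds than this note shows. Statements on the series, on what has been measured and on what is new or still open speak of the compounds shown alone.

Compound 1 `O=[N+]([O-])c1ccc(CN2CCC(n3cc(CC(OCc4cc(-c5ccc(Br)cc5)no4)c4ccc(Br)cc4)nn3)CC2)cc1` is one of two measured members of the series. In an ADME assay on cells (Fibroblast, Homo sapiens) for cytotoxicity, with a stated time of 48 h (on this read-out lower numbers stand for stronger inhibition and higher numbers for weaker inhibition), compound 1 returns only the limit > 25000 nM. Compound 2 `COc1cccc(-c2cc(COC(Cc3cn(C4CCN(Cc5ccc([N+](=O)[O-])cc5)CC4)nn3)c3ccc(Br)cc3)on2)c1` differs from compound 1 by a 3-methoxyphenyl in place of a 4-bromophenyl on an aromatic carbon. In this assay compound 2 likewise returns only the limit > 25000 nM. The step that the two limits leave unreadable from compound 1 to compound 2 therefore cannot be read, since both ends sit at the limit of > 25000 nM in this assay, at which 2 of the 2 values shown sit; compound 2 stands at that limit and nowhere more definite.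

Compound 3 `O=[N+]([O-])c1ccc(CN2CCC(n3cc(CC(OCc4cc(-c5ccccc5Br)no4)c4ccc(Br)cc4)nn3)CC2)cc1` carries the change (2-bromophenyl in place of 3-methoxyphenyl on an aromatic carbon). Among the measured compounds shown here, the only measured step that touches the same aromatic carbon is the one from compound 1 to compound 2, and that step has no readable size. For the measured compounds named here, no measured step therefore supports any expected movement in this assay beyond the scatter, in either direction. The working expectation for compound 3 is 50000 nM, within 20000 nM to 200000 nM, most likely reported again as a limit. The step that the limit leaves unreadable from compound 2 to compound 3 is thus expected to be flat.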

Compound 3, half-maximal inhibitory concentration: > 25000 nM
Compound 3: a limit, no number; the forecaster's own chance of this, stated with the estimate: 80%; the middle value lies beyond the limit too.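

No new step can be read from compound 1, compound 2 or compound 3, as each returns only a limit in this assay: the limit of > 25000 nM in this assay, at which 3 of the 3 values shown sit.

The compounds shown leave open how the 4-bromophenyl, 3-methoxyphenyl and 2-bromophenyl groups on this aromatic carbon compare in this assay, where a numerical value for any of them remains absent.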